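This account rests on a few compounds, and the source may have more. Where it says the series, first, only, none or still open, it means among the compounds named here.

Three compounds share one core, and they differ only in the group on a carbonyl carbon of the side ester. Compound 1 `CCCCCCCCCCC[C@@H](C[C@@H]1OC(=O)[C@H]1CCCCCC)OC(=O)[C@H](CC(C)C)NC(=O)OC(C)(C)C` gives only a limit of > 25000 nM in an assay on COS-7 cells for inhibition of diacylglycerol lipase-alpha (Homo sapiens), read by scintillation counting; on this read-out higher numbers stand for weaker inhibition and lower numbers for stronger inhibition. Compound 2 `CCCCCCCCCCC[C@@H](C[C@@H]1OC(=O)[C@H]1CCCCCC)OC(=O)CNC(=O)OCc1ccccc1` likewise gives only a limit of > 25000 nM in this assay. Going by the values given here, compound 3 `CCCCCCCCCCC[C@@H](C[C@@H]1OC(=O)[C@H]1CCCCCC)OC(=O)[C@H](C)NC=O` gives 43 nM in this assay, the only measured number here. Compound 1 and compound 2 sit at the limit (the limit of > 25000 nM in this assay, at which 2 of the 3 values shown sit). Among the compounds with values here, the one measured step at this position, an at least 580-fold lower number from compound 2 to compound 3 (2.76 log units; beyond the scatter), is large. Compound 4 `CCCCCCCCCCC[C@@H](C[C@@H]1OC(=O)[C@H]1CCCCCC)OC(=O)[C@@H]1CCCN1C=O` is not yet measured; it carries a group of 7 heavy atoms (5 carbon, 1 nitrogen, 1 oxygen; one five-membered non-aromatic ring with 1 hetero atom) in place of a group of 5 heavy atoms (3 carbon, 1 nitrogen, 1 oxygen; no ring), on a carbonyl carbon. That measured step removed a far larger group than the one now entering, so it gives little guidance; the change expected here, a 2.3-fold higher number from compound 3 to compound 4 (0.37 log units; beyond the scatter), is therefore modest. Compound 4 is estimated at 100 nM in this assay, within a range from 20 nM to 1500 nM.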

Compound 4, half-maximal inhibitory concentration: 1100 nM
For compound 4 the middle estimate is 11-fold (1.04 log units) below the measured one; low and high end bracket the measured number.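

In this assay, 1-formylpyrrolidin-2-yl in place of the smaller open group gives a 26-fold higher number from compound 3 to compound 4 (1.41 log units; beyond the scatter), so even a modest change in this small group moves the number strongly. The ring group still improves on ((benzyloxycarbonyl)amino)methyl, with an at least 22-fold lower number from compound 2 to compound 4 (1.35 log units; beyond the scatter). That step starts from a limit, not a measured number: the limit of > 25000 nM in this assay, at which 2 of the 4 values shown sit.

The compounds shown leave open whether the ring itself or the lost amide hydrogen accounts for the rise, as both change together. An open-chain formamide with a methyl on its nitrogen would separate the two.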